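Furan to thiophene swap on the chloro analogue

The source may report more compounds than this note shows. Statements on the series, on what has been measured and on what is new or still open speak of the compounds shown alone.

Three compounds of the series are measured in a functional assay on A549 cells (Homo sapiens), read by sulforhodamine B assay, with a stated time of 5 days; on this read-out higher numbers stand for weaker inhibition of growth and lower numbers for stronger inhibition of growth. Compound 1 `OC[C@H]1O[C@@H](n2cc(F)c3c(-c4ccoc4)ncnc32)[C@H](O)[C@@H]1O` gives 60 nM. Compound 2 `OC[C@H]1O[C@@H](n2cc(F)c3c(-c4ccsc4)ncnc32)[C@H](O)[C@@H]1O` gives 380 nM. Compound 3 `OC[C@H]1O[C@@H](n2cc(Cl)c3c(-c4ccoc4)ncnc32)[C@H](O)[C@@H]1O` gives 1100 nM, the highest number of the three. Compound 4 `OC[C@H]1O[C@@H](n2cc(Cl)c3c(-c4ccsc4)ncnc32)[C@H](O)[C@@H]1O` is not yet measured in this assay.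

The change from compound 1 to compound 2 is thiophen-3-yl in place of furan-3-yl on an aromatic carbon. It made the step of a 6.3-fold higher number from compound 1 to compound 2 (0.80 log units; beyond the scatter). The cores of compound 1 and compound 3 differ as chloro in place of fluoro on an aromatic carbon, which made the step of an 18-fold higher number from compound 1 to compound 3 (1.26 log units; beyond the scatter).

The change from compound 3 to compound 4 is thiophen-3-yl in place of furan-3-yl on an aromatic carbon. Its place is described in the same words as for the change from compound 1 to compound 2, so it is taken as the same change, this time made on the core of compound 3. Among the compounds with values here, the expected step in this assay is a 5.0-fold higher number from compound 3 to compound 4 (0.70 log units; beyond the scatter), set alongside the earlier step of a 6.3-fold higher number from compound 1 to compound 2 (0.80 log units; beyond the scatter) and widened somewhat: only one earlier instance of the change is known, and the cores differ. Compound 4 is therefore expected to give about 5500 nM, with a range from 1800 nM to 18000 nM.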

Compound 4, concentration for 50% growth inhibition: 380 nM
Beside the measured number, compound 4's estimate is 14-fold (1.16 log units) above it, and the stated range ends above it.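

In this assay, thiophen-3-yl in place of furan-3-yl does not carry from one core to the other, and on the chloro core the step is a 2.9-fold lower number from compound 3 to compound 4 (0.46 log units; beyond the scatter), opposite in direction to the step on the fluoro core: the same change on two cores in this assay, a 6.3-fold higher number (0.80 log units; beyond the scatter) from compound 1 to compound 2 and a 2.9-fold lower number (0.46 log units; beyond the scatter) from compound 3 to compound 4, 18-fold (1.26 log units) apart, beyond the scatter of two such steps

Chloro in place of fluoro does not carry either, since the large step seen with furan-3-yl gives way to no change at the digits printed from compound 2 to compound 4 (within the scatter) with thiophen-3-yl: the same change on two cores in this assay, an 18-fold higher number (1.26 log units; beyond the scatter) from compound 1 to compound 3 and no change at the digits printed (within the scatter) from compound 2 to compound 4, 18-fold (1.26 log units) apart, beyond the scatter of two such steps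

In these four compounds, the effect of each change therefore depends on the group at the other place, so the two steps cannot simply be added; this rests on a single pair of cores for each change and does not show what lies behind the dependence or whether it extends beyond this set.

The compounds shown leave open whether phenyl or an amine on the same aromatic carbon would follow the furan-3-yl or the thiophen-3-yl pattern. As far as these compounds go, how bromo or methyl would behave in place of fluoro and chloro also remains open.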